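This account rests on a few compounds, and the source may have more. Where it says the series, first, only, none or still open, it means among the compounds named here.

Compounds measured so far:

Compound 1, `O=C(/C(=C\c1ccc(F)c([N+](=O)[O-])c1)SCc1ccc(F)cc1)c1ccc(F)cc1`, 1000 nM
Compound 2, `O=C(O)c1ccc(C(=O)/C(=C\c2ccc(F)c([N+](=O)[O-])c2)SCc2ccc(F)cc2)cc1`, 1000 nM
Compound 3, `O=C(O)c1ccc(C(=O)/C(=C\c2ccc(F)c([N+](=O)[O-])c2)SCc2ccc(Cl)cc2Cl)cc1`, 1000 nM

In a functional assay on DU-145 cells (Homo sapiens) for inhibition, read by trypan blue exclusion, with a stated time of 96 h (on this read-out higher numbers stand for weaker inhibition of growth and lower numbers for stronger inhibition of growth), compound 2 stands level with compound 1 and compound 3 at the digits recorded; its nearest neighbour on the numbers is compound 1 and its furthest is compound 3, and neither gap is beyond the scatter. The two steps seen so far are no change at the digits printed from compound 1 to compound 2 (within the scatter) and no change at the digits printed from compound 2 to compound 3 (within the scatter); both left the read-out unchanged within the scatter, and both altered parts of the molecule other than the 4-fluoro-3-nitrophenyl ring.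

The next compound is compound 4, `O=C(O)c1ccc(C(=O)/C(=C\c2ccc(O)c([N+](=O)[O-])c2)SCc2ccc(F)cc2)cc1`. It differs from compound 2 by hydroxy in place of fluoro on an aromatic carbon. Among the compounds with values here, no measured step touches this ring, so there is no direct precedent for the change; the only guidance is that the two changes made elsewhere, no change at the digits printed from compound 1 to compound 2 (within the scatter) and no change at the digits printed from compound 2 to compound 3 (within the scatter), gave no movement. On that basis the step from compound 2 to compound 4 in this assay is expected to be no change at the digits printed from compound 2 to compound 4 (within the scatter), with no change beyond the scatter in either direction. Compound 4 is therefore estimated at 1000 nM, in a range from 400 nM to 3000 nM.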

Compound 4, concentration for 50% growth inhibition: > 100000 nM
Compound 4: a limit, no number (the forecaster's own chance of this, stated with the estimate: 20%); middle value at least 100-fold (2.00 log units) away from the limit.
By their numbers in this assay, from the lowest: compounds 1, 2 and 3 (each within the scatter of the next). At a limit, above all of these: compound 4.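

The 4-fluoro-3-nitrophenyl ring is the first part of the molecule shown to matter in this assay: hydroxy in place of fluoro on the aromatic carbon ortho to the nitro group gave an at least 100-fold higher number from compound 2 to compound 4 (2.00 log units; beyond the scatter), whereas the changes made at the other two places stayed within the scatter. For compound 4 the result is a limit of the assay and not a number, > 100000 nM. A swap of one heavy atom for one heavy atom, bringing in one hydrogen-bond donor and one hydrogen-bond acceptor by the count, is thus enough for a large step at this position, and the true size of that step stays unknown: the limit of > 100000 nM in this assay, at which 1 of the 4 values shown sits.

The compounds shown leave open whether fluoro itself is needed at this carbon or hydroxy alone is poorly tolerated there, a question that a methoxy group, an amine or a chloro group at the same place would help to settle. They also leave open whether the same exchange has as large an effect on the frame of compound 1 or of compound 3, and what part the nitro group plays.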